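Ring enlargement at the amino substituent: compound 3 to 4

This account rests on a few compounds, and the source may have more. Where it says the series, first, only, none or still open, it means among the compounds named here.

For the measured compounds named here, compound 3 `FC(F)(F)c1ccc(Nc2nc(N3CCC3)nc3sc(Nc4c(Cl)cccc4Cl)nc23)cc1` gives 25 nM in a functional assay on HEK293 cells for antagonist activity at transient receptor potential cation channel subfamily V member 1 (Rattus norvegicus), read by calcium flux (on this read-out higher numbers stand for weaker inhibition and lower numbers for stronger inhibition), and stands highest of the three numbers measured so far; compound 1 `FC(F)(F)c1ccc(Nc2ncnc3sc(Nc4c(Cl)cccc4Cl)nc23)cc1` gives 3 nM and compound 2 `Cc1cccc(C)c1Nc1nc2c(Nc3ccc(C(F)(F)F)cc3)ncnc2s1` gives 6 nM. Going by the values given here, the one step that touches the same position is an 8.3-fold higher number from compound 1 to compound 3 (0.92 log units; beyond the scatter), which brought the azetidin-1-yl group onto the shared core. The step of a 2.0-fold higher number from compound 1 to compound 2 (0.30 log units; within the scatter) concerns the other anilino group and does not bear on the present change. Compound 4 `FC(F)(F)c1ccc(Nc2nc(N3CCCC3)nc3sc(Nc4c(Cl)cccc4Cl)nc23)cc1` differs from compound 3 in one place: pyrrolidin-1-yl in place of azetidin-1-yl on an aromatic carbon. Among the compounds with values here, no measured pair shows what happens when one such ring is exchanged for a ring one atom larger at this carbon, so the size of the effect cannot be read from the series; the earlier step only shows that the number moved upward when this carbon was first occupied. For compound 4 a small upward drift is expected, the expected step being a 1.4-fold higher number from compound 3 to compound 4 (0.15 log units; within the scatter). Compound 4 is estimated at 35 nM, with a range from 12 nM to 100 nM.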

Compound 4, half-maximal inhibitory concentration: 36 nM
Estimate against measurement, compound 4: 1.0-fold (0.01 log units) below; low and high end bracket the measured number.
By their numbers in this assay, from the lowest: compounds 1 and 2 (each within the scatter of the next); then compounds 3 and 4 (each within the scatter of the next).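

In this assay, for the compounds shown here, the first ring exchange at this carbon gives a 1.4-fold higher number from compound 3 to compound 4 (0.16 log units; within the scatter) and so leaves azetidin-1-yl and pyrrolidin-1-yl unresolved on this read-out. The step from hydrogen, a 12-fold higher number from compound 1 to compound 4 (1.08 log units; beyond the scatter), now stands with an 8.3-fold higher number from compound 1 to compound 3 (0.92 log units; beyond the scatter) and shows that each of the two rings at this carbon gives a number beyond the scatter of the unsubstituted compound 1, with no exception among these three compounds. The data on hand give no reason for either step.

Still open, as far as these compounds go, is whether piperidin-1-yl, morpholin-4-yl or an open-chain dimethylamino group at this carbon would stay with compound 3 and compound 4 or return toward compound 1. Also open, from the compounds shown here alone, is how a pyrrolidin-1-yl group at this carbon behaves alongside the 2,6-dimethylphenyl group of compound 2.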